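Methyl Restored on the Aromatic Ring of Compound 3

The compounds below may be only part of what the source reports. "The series", "measured", "known", "first", "only" and "open" are said of these compounds alone.

For the measured compounds named here, compound 3 `Cc1coc2c3c(ccc2c1=O)OC[C@H]1[C@@H]3Nc2ccccc2C1(C)C` holds the only number among the three measured compounds: in a functional assay on MDA-MB-231 cells (Homo sapiens) for antiproliferative activity, read by MTT assay (a higher number here means a weaker inhibitor, a lower number a stronger inhibitor), compound 3 gives 93800 nM. Compound 1 `Cc1ccc2c(c1)C(C)(C)[C@H]1COc3ccc4c(=O)c(C)c(C)oc4c3[C@H]1N2` gives > 100000 nM, which is a limit of the assay. Compound 2 `Cc1oc2c3c(ccc2c(=O)c1C)OC[C@H]1[C@@H]3Nc2ccccc2C1(C)C` likewise gives > 100000 nM, again a limit. The step of an at least 1.0-fold lower number from compound 2 to compound 3 (0.02 log units; that floor lies within the scatter) stays within the scatter. Compound 4 `Cc1ccc2c(c1)C(C)(C)[C@H]1COc3ccc4c(=O)c(C)coc4c3[C@H]1N2` differs from compound 3 by methyl in place of hydrogen on an aromatic carbon. The mirror of this change appears as a step that the two limits leave unreadable from compound 1 to compound 2, with both values sitting at the limit of > 100000 nM in this assay, at which 2 of the 3 values shown sit. Nothing measured therefore points to a step beyond the scatter, and compound 4 is expected to give 95000 nM, with a range from 45000 nM to 200000 nM, an expected step of a 1.0-fold higher number from compound 3 to compound 4 (0.01 log units; within the scatter).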

Compound 4, half-maximal inhibitory concentration: > 100000 nM
Compound 4: no number, only a limit; the forecaster's own chance of this, stated with the estimate: 50%; at least 1.0-fold (0.02 log units) between middle value and limit.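

As far as these compounds go, with methyl on this aromatic carbon, compound 4 gives only a limit, so the change reads as an at least 1.0-fold higher number from compound 3 to compound 4 (0.02 log units; that floor lies within the scatter), and its true size stays unknown. Unlike the earlier step at this place, this one has a readable floor, set against the only measured number, and it shows no move toward a lower number in this assay. The step between compound 1 and compound 4 cannot be read, and the limit now holds most of the compounds shown: the limit of > 100000 nM in this assay, at which 3 of the 4 values shown sit.

From the compounds shown here alone, whether an amine or a methoxy group at this carbon would bring a measured number in this assay remains open.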